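A few compounds are considered here, and "the series" means these few. Any claim that something is new, unique, unknown or untested is made for them only; others in the source may bear on it.

Measured so far in an assay on HEK293 cells for inhibition of Steryl-sulfatase (Homo sapiens), tested at 1 uM; a lower number here means a weaker effect, a higher number a stronger effect of the compound at the concentration tested:
compound 1 `CCN(Cc1ccccn1)c1cccc(C(=O)N2CCc3ccc(OS(N)(=O)=O)cc3C2)c1` gives 19.9%
compound 2 `NS(=O)(=O)Oc1ccc2c(c1)CN(C(=O)c1cccc(N3CCC(N4CCCCC4)CC3)c1)CC2` gives 8%
compound 3 `NS(=O)(=O)Oc1ccc2c(c1)CN(C(=O)c1cccc(N3CCCCC3)c1)CC2` gives 11.9%

Compound 3 holds the second highest of the three numbers, yet neither step leading to it reaches beyond the scatter: a number 3.9 percentage points higher from compound 2 to compound 3 (within the scatter) and a number 8 percentage points lower from compound 1 to compound 3 (within the scatter). On these numbers the three compounds are not separable.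

Next in the series is compound 4 `CC(C)CCN(CCC(C)C)c1cccc(C(=O)N2CCc3ccc(OS(N)(=O)=O)cc3C2)c1`. Relative to compound 3 the change is diisopentylamino in place of piperidin-1-yl on an aromatic carbon. Within the data shown here, of the measured steps, only the one between compound 1 and compound 3 touches the same place, where an acyclic amino group on the aromatic carbon was exchanged for the ring; that step stayed within the scatter. The step between compound 2 and compound 3 concerns a saturated ring carbon and bears little on this exchange. Going back from the ring to an acyclic amino group is therefore expected to move the number in this assay at most slightly upward, not beyond the scatter. For compound 4 the expected step is a number 6.1 percentage points higher from compound 3 to compound 4 (within the scatter). Compound 4 is estimated at 18%, in a range from 5% to 35%.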

Compound 4, a percentage reported as inhibition, at one concentration (the size of the read-out at that concentration, not a potency): 75.9%
For compound 4 the middle estimate is 57.9 percentage points below the measured one; measured number outside the range, above it.
By their numbers in this assay, from the lowest: compounds 2, 3 and 1 (each within the scatter of the next, the first and the last beyond it); then compound 4.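

In this assay, among these compounds, this position on the aromatic ring proves far more sensitive than the earlier compounds indicated: diisopentylamino in place of piperidin-1-yl gives a large gain (a number 64 percentage points higher from compound 3 to compound 4 (beyond the scatter)), and diisopentylamino in place of ethyl((pyridin-2-yl)methyl)amino gives another (a number 56 percentage points higher from compound 1 to compound 4 (beyond the scatter)). An amino group that is open at the nitrogen is therefore not enough on its own, as compound 1 shares that feature yet remains within the scatter of compound 3; among the groups shown, only diisopentylamino carries no ring. No available data explain the size of this gain.

The compounds shown leave open whether the gain follows the branched chain ends, the length of the two chains or the presence of both chains. A dibutylamino or an isopentyl(methyl)amino group on the same aromatic carbon would help separate these readings.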